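Replacing a methylpyridine with a methoxyphenyl: expected lipophilicity

A few compounds are considered here, and "the series" means these few. Any claim that something is new, unique, unknown or untested is made for them only; others in the source may bear on it.

Measured so far:
compound 1 `CC[C@@H](Nc1c(C#N)c(-c2ccc(-c3ncccc3C)cc2)nc2cnccc12)C(N)=O`: 2
compound 2 `CCOc1ccccc1-c1ccc(-c2nc3cnccc3c(N[C@H](CC)C(=O)NS(C)(=O)=O)c2C#N)cc1`: 2.2
compound 3 `CN(CC(N)=O)c1c(C#N)c(-c2ccc(Br)cc2)nc2cnccc12`: 2.1

In a physicochemical assay for lipophilicity, read by HPLC, at pH 7.5 (a lower number here means a more polar compound, a higher number a more lipophilic compound), compound 1 gives 2, the lowest of the three numbers, although compound 3 and compound 2 both lie within the scatter of it, so the three cannot be ordered. Compound 4 `CC[C@@H](Nc1c(C#N)c(-c2ccc(-c3ccccc3OC)cc2)nc2cnccc12)C(N)=O` differs from compound 1 in a single place: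

2-methoxyphenyl in place of 3-methylpyridin-2-yl on an aromatic carbon

Going by the values given here, no measured pair isolates this change, so nothing in the data fixes its size. The expectation is nonetheless a moderate rise beyond the scatter rather than no change. The expected step is a number 0.60 log units higher from compound 1 to compound 4 (beyond the scatter). Compound 4 is therefore estimated at 2.6 in this assay, with a likely range from 2.1 to 3.1.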

Compound 4, distribution coefficient: 2.7
The estimate for compound 4 lay 0.10 log units below the measured number, and the stated range covers the measured number.
By their numbers in this assay, from the lowest: compounds 1, 3 and 2 (each within the scatter of the next); then compound 4.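

In this assay, going by these compounds alone, the change from 3-methylpyridin-2-yl to 2-methoxyphenyl gives a number 0.70 log units higher from compound 1 to compound 4 (beyond the scatter) and provides the first comparison here of compounds differing in one place. It shows that at this aromatic carbon, para to a large group, exchanging one aromatic group for another can move the reading beyond the scatter. Nothing measured here explains the step.

The compounds shown leave open how much of the step follows from removing the ring nitrogen and how much from adding the methoxy group. A 2-methylphenyl group at this place would help separate the two.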